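The source may report more compounds than this note shows. Statements on the series, on what has been measured and on what is new or still open speak of the compounds shown alone.

Compound 1 `COc1ccc2c(=O)c(/C=C/C(=O)Nc3ccc(C)cc3)coc2c1`: > 200000 nM
Compound 2 `COc1ccc2c(=O)c(/C=C/C(=O)Nc3ccccc3)coc2c1`: > 200000 nM

In a functional assay on L02 cells (Homo sapiens) for inhibition, read by MTT assay, with a stated time of 48 h (on this read-out lower numbers stand for stronger inhibition and higher numbers for weaker inhibition), compound 1 gives only a limit of the assay, > 200000 nM. In this assay compound 2 likewise gives only a limit, > 200000 nM. The step that the two limits leave unreadable from compound 1 to compound 2, hydrogen in place of methyl on an aromatic carbon, therefore cannot be sized, since both ends of it are limits rather than numbers. Compound 2 thus stands at the limit of > 200000 nM in this assay, at which 2 of the 2 values shown sit, with no measured number to place it more closely. Compound 3 `COc1ccc2c(=O)c(/C=C/C(=O)Nc3ccc(Cl)cc3)coc2c1` differs from compound 2 by chloro in place of hydrogen on an aromatic carbon. For the measured compounds named here, the only measured step bears on this change merely as a pair of limits, so no direction or size beyond the scatter can be read for this assay. Compound 3 is expected to remain at the same limit, with an estimated step of a number no higher from compound 2 to compound 3 (the limit leaves the size open). The estimate for compound 3 in this assay is 200000 nM, within 100000 nM to 400000 nM.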

Compound 3, half-maximal inhibitory concentration: > 200000 nM
Compound 3: a limit, no number; the forecaster's own chance of this, stated with the estimate: 80%; the middle value lies on the limit itself.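

Compound 3 gives only a limit in this assay (> 200000 nM). For the compounds shown here, with limits alone, no step among compound 1, compound 2 and compound 3 can be read. The compounds shown leave open what number each would reach and whether hydrogen, methyl or chloro at this place changes inhibition at all.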